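Ester Swap at the Dihydropyridine Ester Position

The compounds below may be only part of what the source reports. "The series", "measured", "known", "first", "only" and "open" are said of these compounds alone.

Compound 3 `COC(=O)C1=C(C)NC(C)=C(C(=O)OCc2cc([N+](=O)[O-])cc([N+](=O)[O-])c2)C1c1cccc([N+](=O)[O-])c1` is tested in a functional assay on HEK293 cells for antagonist activity at Voltage-dependent L-type calcium channel subunit alpha-1D (Rattus norvegicus), read by FLIPR (on this read-out higher numbers stand for weaker inhibition and lower numbers for stronger inhibition), where compound 3 gives 40 nM. Compound 1 `CCCCC1=C(C(=O)OCC)C(c2cccc([N+](=O)[O-])c2)C(C(=O)OCC)=C(C)N1` gives 20 nM and compound 2 `CCOC(=O)C1=C(C)NC(CO)=C(C(=O)OCC)C1c1cccc([N+](=O)[O-])c1` gives 45 nM; the number for compound 3 lies within the usual scatter of both of them, so no order among the three is established. Among the measured compounds shown here, the one measured step, a 2.3-fold higher number from compound 1 to compound 2 (0.35 log units; beyond the scatter), concerns a change at a saturated chain carbon bound to a double-bonded ring carbon, not the ester that is altered here.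

Compound 4 `COC(=O)C1=C(C)NC(C)=C(C(=O)OCCCCc2ccc(OC)cc2)C1c1cccc([N+](=O)[O-])c1` differs from compound 3 in one place: 3-(4-methoxyphenyl)propyl in place of 3,5-dinitrophenyl on a saturated chain carbon bound to an oxygen next to a carbonyl group. For the measured compounds named here, no measured step touches this ester, and the whole spread among compounds 1, 2 and 3 stays within the scatter. The step of a 1.1-fold higher number from compound 3 to compound 4 (0.05 log units; within the scatter) is therefore expected to be small, with no direction beyond the scatter predicted for this assay. Compound 4 is estimated at 45 nM in this assay, with a range from 12 nM to 180 nM.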

Compound 4, half-maximal inhibitory concentration: 38 nM
Compound 4: the middle estimate sits 1.2-fold (0.07 log units) above what was measured, and the stated range covers the measured number.
By their numbers in this assay, from the lowest: compounds 1, 4, 3 and 2 (each within the scatter of the next, the first and the last beyond it).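

The change gave a 1.1-fold lower number from compound 3 to compound 4 (0.02 log units; within the scatter) in this assay when 3-(4-methoxyphenyl)propyl replaced 3,5-dinitrophenyl on a saturated chain carbon bound to an oxygen next to a carbonyl group. Among the compounds shown here, this is the first measured step at this ester, and it shows that two quite different groups, one with 4 hydrogen-bond acceptors and 2 double bonds outside aromatic rings, the other with 1 hydrogen-bond acceptor and none of those double bonds, give numbers within the scatter of each other. No further measurement bears on why the number holds.

Going by these compounds, whether an amine or a carboxylic acid on this chain would also stay within the scatter remains open. The compounds shown also do not tell whether the same exchange would behave alike on the core of compound 1.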